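Compound 3: swapping methylsulfanyl for methylsulfonyl

The source may hold more compounds than are shown below. What is called first, only, known or untested is meant among the compounds shown, and "the series" means these compounds.

- Compound 1 `c1ccc(-c2nc3cc[nH]cc-3n2)cc1`: 2.5 mg/kg
- Compound 2 `CSc1ccc(-c2nc3cc[nH]cc-3n2)cc1`: 4 mg/kg

Both compounds were tested in a functional assay on the whole organism with Canis familiaris (Canis lupus familiaris) as the target; a lower number here means that less compound is needed, a higher number that more compound is needed for the effect. For the measured compounds named here, compound 2 gives 4 mg/kg, and it cannot be told apart from its only measured neighbour, since a 1.6-fold higher number from compound 1 to compound 2 (0.20 log units; within the scatter).

Compound 3 `CS(=O)(=O)c1ccc(-c2nc3cc[nH]cc-3n2)cc1` keeps the core of compound 2 and changes in one place, with methylsulfonyl in place of methylsulfanyl on an aromatic carbon.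

Going by the values given here, only one measured step bears on this change, and it touches the same aromatic carbon: a 1.6-fold higher number from compound 1 to compound 2 (0.20 log units; within the scatter). That step puts methylsulfanyl in place of hydrogen, so it is a different swap and only an indirect guide. Among the compounds with values here, no measurement yet shows what methylsulfonyl does here. With so little evidence, the expectation in this assay is for no clear shift in either direction, and the range has to stay wide.

The estimated change is a 1.3-fold lower number from compound 2 to compound 3 (0.12 log units; within the scatter). For compound 3 the expected value is about 3 mg/kg, with an estimated range of 1 mg/kg to 9 mg/kg.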

Compound 3, dose for half-maximal effect: 7.5 mg/kg
Compound 3: middle estimate off by 2.5-fold (0.40 log units), on the low side, and the stated range covers the measured number.
By their numbers in this assay, from the lowest: compounds 1, 2 and 3 (each within the scatter of the next, the first and the last beyond it).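

In this assay, this aromatic carbon now shows a step that clears the usual scatter: methylsulfonyl in place of hydrogen gives a 3.0-fold higher number from compound 1 to compound 3 (0.48 log units; beyond the scatter), so more compound is needed for the effect. For the compounds shown here, this is modest, but the earlier pair could not show even this much, as its only step lay within the scatter. The direct swap of methylsulfanyl for methylsulfonyl remains too small to read on its own, at a 1.9-fold higher number from compound 2 to compound 3 (0.27 log units; within the scatter), so the two sulfur groups cannot be ranked against each other, and only the hydrogen and methylsulfonyl ends of the series separate. No measurement at hand offers a reason for the separation between those two ends.

With only hydrogen and two sulfur groups at this position, the compounds shown leave open whether other groups on the same aromatic carbon, such as an amine, a carboxylic acid or a longer chain, would need less compound or more. They also leave open whether the modest step from hydrogen to methylsulfonyl would hold up in repeated measurements, since it lies not far beyond the scatter.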